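The compounds below may be only part of what the source reports. "The series", "measured", "known", "first", "only" and "open" are said of these compounds alone.

Measured compounds:
Compound 1 `COc1ccc([C@H]2CC(=O)N(c3cc(N)cc(F)c3)C2)cc1OC1CCCC1` — > 10000 nM
Compound 2 `COc1ccc([C@H]2CC(=O)N(c3ccccc3C(F)(F)F)C2)cc1OC1CCCC1` — > 10000 nM

In a functional assay on HEK293 cells (Homo sapiens) for cytotoxicity (on this read-out lower numbers stand for higher toxicity in this test and higher numbers for lower toxicity in this test), compound 1 gives no number but only a limit of the assay, > 10000 nM. Compound 2 likewise gives only a limit in this assay, > 10000 nM. Going by the values given here, both values therefore sit at the limit of > 10000 nM in this assay, at which 2 of the 2 values shown sit, and the single measured step, a step that the two limits leave unreadable from compound 1 to compound 2, cannot be sized from the two limits; it shows only that exchanging the aryl group on the amide-type nitrogen in a ring did not bring either compound below the limit.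

Compound 3 `COc1ccc([C@H]2CC(=O)N(c3cccc(S(C)(=O)=O)c3)C2)cc1OC1CCCC1` is the next member of the series. It differs from compound 2 in one place: 3-(methylsulfonyl)phenyl in place of 2-(trifluoromethyl)phenyl on an amide-type nitrogen in a ring. Among the compounds with values here, the only measured step, a step that the two limits leave unreadable from compound 1 to compound 2, is the one that bears on this change, and it is unreadable, so no direction can be taken from it. Compound 3 is therefore expected to remain at the limit as well, with a step that the limit leaves unreadable from compound 2 to compound 3 that is estimated to stay within the scatter. The estimate for compound 3 in this assay is 15000 nM, with a range from 8000 nM to 40000 nM.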

Compound 3, half-maximal cytotoxic concentration: > 10000 nM
Compound 3: no number, only a limit; the forecaster's own chance of this, stated with the estimate: 85%; the middle value does not contradict the limit.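

Compound 3, like compound 1 and compound 2, gives only a limit in this assay, so neither new step, from compound 2 or from compound 1 to compound 3, can be read: the limit of > 10000 nM in this assay, at which 3 of the 3 values shown sit.

The compounds shown leave open how the three groups on the amide-type nitrogen compare, since none yields a number.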